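Working notes: amino in place of fluoro, compound 4

A few compounds are considered here, and "the series" means these few. Any claim that something is new, unique, unknown or untested is made for them only; others in the source may bear on it.

Compound 1 `COc1ccc(CNc2cc(OC)c(OC)c(OC)c2)cc1Cl`: 41700 nM
Compound 2 `COc1ccc(CNc2cc(OC)c(OC)c(OC)c2)cc1Br`: 48100 nM
Compound 3 `COc1ccc(CNc2cc(OC)c(OC)c(OC)c2)cc1F`: 32200 nM

All three values come from a functional assay on HCT-116 cells (Homo sapiens) for inhibition, read by MTT assay, with a stated time of 48 h; a higher number here means a weaker inhibitor, a lower number a stronger inhibitor. Compound 3, at 32200 nM, stands within the scatter of compound 1 and compound 2. The unmeasured compound 4 `COc1ccc(CNc2cc(OC)c(OC)c(OC)c2)cc1N` differs from compound 3 as follows: amino in place of fluoro on an aromatic carbon. The nearest evidence is the exchange among chloro, bromo and fluoro: a 1.2-fold higher number from compound 1 to compound 2 (0.06 log units; within the scatter), a 1.3-fold lower number from compound 1 to compound 3 (0.11 log units; within the scatter) and a 1.5-fold lower number from compound 2 to compound 3 (0.17 log units; within the scatter), all within the scatter. Within the data shown here, no measured compound carries amino, so these steps offer only weak guidance and no direction. The expected step is a 1.1-fold lower number from compound 3 to compound 4 (0.03 log units; within the scatter), with nothing beyond the scatter anticipated. For compound 4 the estimate is 30000 nM, with an expected range of 10000 nM to 70000 nM.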

Compound 4, half-maximal inhibitory concentration: 8270 nM
Compound 4: middle estimate off by 3.6-fold (0.56 log units), on the high side, and the stated range ends above it.
By their numbers in this assay, from the lowest: compound 4; then compounds 3, 1 and 2 (each within the scatter of the next).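

In this assay, amino on this aromatic carbon, ortho to a methoxy group, stands apart from all three halogens (a 3.9-fold lower number from compound 3 to compound 4 (0.59 log units; beyond the scatter)), (a 5.0-fold lower number from compound 1 to compound 4 (0.70 log units; beyond the scatter)) and (a 5.8-fold lower number from compound 2 to compound 4 (0.76 log units; beyond the scatter)). The exchanges among the halogens had stayed within the scatter, so they gave no sign that this position responds to a change of group, whereas compound 4 now shows that it does. No available evidence bears on what lies behind this step.

On these data alone, it remains open whether the step is particular to amino or extends to methylamino, dimethylamino, hydroxyl or an acetamide at this position.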